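This account rests on a few compounds, and the source may have more. Where it says the series, first, only, none or still open, it means among the compounds named here.

Working notes on the series. Three compounds carry a number in an in vitro functional assay on 1321-N1 cells for agonist activity at Free fatty acid receptor 1 (Homo sapiens), read by fluorescence, spectrophotometry and calcium flux; on this read-out lower numbers stand for an effect already at smaller amounts and higher numbers for an effect only at larger amounts of compound. Compound 1 `O=C(O)C1CC1c1ccc(C#Cc2cc(Cl)nc(Cl)c2)cc1` gives 42.7 nM in this assay. Compound 2 `Cc1cc(C#Cc2ccc(CCC(=O)O)cc2)nc(Cl)n1` gives 2750 nM. Compound 3 `O=C(O)CCc1ccc(C#Cc2ccnc(F)c2)cc1` gives 513 nM. Among these three numbers, compound 3 holds the second highest. Its nearest neighbour is compound 2, whose number is higher, and that gap lies beyond the scatter. The furthest is compound 1, whose number is lower, again beyond the scatter. Going by the values given here, no two measured compounds differ in only one place, so there is no measured single-point step to lean on.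

Compound 4 `O=C(O)CCc1ccc(C#Cc2ccncc2)cc1` is the next member and has no number in this assay yet. It differs from compound 3 in one place: hydrogen in place of fluoro on an aromatic carbon. Without a measured step of the same kind, the expectation rests on the structural change alone and stays tentative. The expected step is a move toward a higher number, a 2.1-fold higher number from compound 3 to compound 4 (0.33 log units; beyond the scatter), larger than the scatter but smaller than the gap between compound 3 and compound 2. For compound 4 the estimate in this assay is 1100 nM, with a range from 350 nM to 3500 nM.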

Compound 4, half-maximal effective concentration: 4070 nM
The estimate for compound 4 lay 3.7-fold (0.57 log units) below the measured number, outside the stated range (above it).
By their numbers in this assay, from the lowest: compound 1; then compound 3; then compounds 2 and 4 (each within the scatter of the next).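

Going by these compounds alone, this is the first single-place step the series offers: with hydrogen in place of fluoro on an aromatic carbon, next to the ring nitrogen and meta to a large group, this assay gives a 7.9-fold higher number from compound 3 to compound 4 (0.90 log units; beyond the scatter). The exchange removes a single heavy atom and leaves the rest of the structure unchanged, yet the step lies beyond the scatter, so this position is not indifferent to its substituent. Within the data shown here, on this pair, the fluoro-bearing compound 3 is the one that acts at smaller amounts, which the earlier compounds could not show, since none of them differed in only one place.

Going by these compounds, it remains open whether another group at this same position, such as a methoxy group or an amine, would give a number on the side of compound 3, on the side of compound 4, or outside both, and whether the same exchange would give a step of similar size on the core of compound 1. Nothing shown here accounts for the size of this step.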